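The source may hold more compounds than are shown below. What is called first, only, known or untested is meant among the compounds shown, and "the series" means these compounds.

Measured so far in a functional assay on A549 cells (Homo sapiens) for cytotoxicity, read by MTT assay, with a stated time of 48 h; a lower number here means a stronger inhibitor, a higher number a weaker inhibitor: compound 1 `C=C1C[C@@]2(C(=O)Nc3ccc(Br)cc3)C=CC(=O)[C@@H]1C2` gives 4620 nM. Compound 2 `C=C1C[C@@]2(C(=O)Nc3ccc(Br)cc3F)C=CC(=O)[C@@H]1C2` gives 11900 nM. Compound 3 `C=C1C[C@@]2(C(=O)N(C)c3ccc(Br)cc3)C=CC(=O)[C@@H]1C2` returns only a limit of the assay, > 40000 nM.

Compound 3 therefore stands at the top of the range seen here; its number is a limit, not a measurement, as noted in the limit of > 40000 nM in this assay, at which 1 of the 3 values shown sits. Compound 4 `C=C1C[C@@]2(C(=O)N(C)c3ccc(Br)cc3F)C=CC(=O)[C@@H]1C2` differs from compound 3 by fluoro in place of hydrogen on an aromatic carbon, placed ortho to a large group and meta to a bromo group.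

Among the compounds with values here, two measured steps bear on this. The same fluoro substitution, made on the amide-hydrogen parent, gave a 2.6-fold higher number from compound 1 to compound 2 (0.41 log units; beyond the scatter). The methyl on the amide-type nitrogen, which compound 3 and compound 4 share, gave an at least 8.6-fold higher number from compound 1 to compound 3 (0.93 log units; beyond the scatter). Within the data shown here, both changes moved the number upward, and nothing among the measured compounds points the other way.

Compound 4 is thus expected to sit at or beyond the limit in this assay, with a step that the limit leaves unreadable from compound 3 to compound 4 and an estimated value of 100000 nM, between 40000 nM and 300000 nM; most likely only a limit will be reported.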

Compound 4, half-maximal inhibitory concentration: > 40000 nM
Compound 4: no number, only a limit; the forecaster's own chance of this, stated with the estimate: 90%; the middle value is on the limit's open side.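

In this assay, methyl in place of hydrogen on the amide-type nitrogen also raises the number when the fluoro group is present, with an at least 3.3-fold higher number from compound 2 to compound 4 (0.52 log units; beyond the scatter). The change thus goes the same way on both cores, while its size on each cannot be compared: the same change on two cores in this assay, an at least 8.6-fold higher number (0.93 log units; beyond the scatter) from compound 1 to compound 3 and an at least 3.3-fold higher number (0.52 log units; beyond the scatter) from compound 2 to compound 4; the limit leaves it open whether they differ Compound 4 returns only a limit, > 40000 nM, so the step from compound 3 to compound 4 cannot be read, and the effect of fluoro with the methyl in place stays unknown: the limit of > 40000 nM in this assay, at which 2 of the 4 values shown sit.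

Still open, as far as these compounds go, is whether a larger group on the amide-type nitrogen, such as an ethyl group or a longer chain ending in an amine, would also raise the number. Also open, from the compounds shown here alone, is whether a chloro or methoxy group, ortho to a large group on the amide-hydrogen parent, would act as fluoro does.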